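Moving the hydroxy group on the amide phenyl ring

The source may report more compounds than this note shows. Statements on the series, on what has been measured and on what is new or still open speak of the compounds shown alone.

Measured compounds:
Compound 1, `O=C(Nc1ccccc1)c1cc2cc(Cl)cc(Br)c2oc1=O`: 16000 nM
Compound 2, `O=C(Nc1cccc(O)c1)c1cc2cc(Cl)cc(Br)c2oc1=O`: 34000 nM

In an assay on isolated protein for inhibition of coagulation factor XII (Homo sapiens), read by HPLC, with stated times of 10 min and 30 min (a lower number here means a stronger inhibitor, a higher number a weaker inhibitor), compound 1 gives 16000 nM and compound 2 gives 34000 nM. Within the data shown here, compound 2 thus stands at the higher of the two numbers, the weaker of the pair, and the single step measured so far, a 2.1-fold higher number from compound 1 to compound 2 (0.33 log units; beyond the scatter), shows that placing a hydroxy on the phenyl ring attached to the amide nitrogen cost a little potency.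

Compound 3, `O=C(Nc1ccccc1O)c1cc2cc(Cl)cc(Br)c2oc1=O`, keeps every atom of compound 2 but joins them differently: 2-hydroxyphenyl in place of 3-hydroxyphenyl on an amide-type nitrogen. The change is small. Among the measured compounds shown here, no measured step moves a hydroxy group from one place on this ring to another, so the step from compound 1 to compound 2 is only an indirect guide: it says the hydroxy group matters modestly at one position, and leaves open how much its position matters. The reasonable expectation is a step within the scatter, with a slight lean toward a lower number, since the two measured compounds bracket a narrow span.

Compound 3 is therefore estimated at about 25000 nM, with a likely range from 10000 nM to 65000 nM. This estimate corresponds to an expected step of a 1.4-fold lower number from compound 2 to compound 3 (0.13 log units; within the scatter).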

Compound 3, half-maximal inhibitory concentration in the coagulation factor XII assay: 7000 nM
The estimate for compound 3 lay 3.6-fold (0.55 log units) above the measured number; measured number below the stated range.
By their numbers in the coagulation factor XII assay, from the lowest: compound 3; then compound 1; then compound 2.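

In the coagulation factor XII assay, the hydroxy group does not have one fixed effect: as 2-hydroxyphenyl on the amide-type nitrogen it gives a 2.3-fold lower number from compound 1 to compound 3 (0.36 log units; beyond the scatter), the opposite direction to the small loss seen earlier with 3-hydroxyphenyl, a 2.1-fold higher number from compound 1 to compound 2 (0.33 log units; beyond the scatter). Changing only where the hydroxy group sits on the ring, with the atoms otherwise the same, gives a 4.9-fold lower number from compound 2 to compound 3 (0.69 log units; beyond the scatter), and this makes compound 3 the strongest inhibitor of the three, so among these compounds the place of the group decides whether adding it helps or hurts. In a physicochemical assay for solubility, at pH 6.5 (on this read-out higher numbers stand for higher solubility and lower numbers for lower solubility), compound 2 gives 1.4 ug/mL and compound 3 gives 0.71 ug/mL, and the same change gives a 2.0-fold lower number from compound 2 to compound 3 (0.29 log units; within the scatter), so the gain in inhibition comes with no solubility difference that can be told apart from ordinary repeat variation, although both compounds have low numbers on that read-out.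

Still open, on these data alone, is whether the hydroxy group itself is needed in 2-hydroxyphenyl, a question that a methoxy group or an amine in its place on the ring would help to settle. Nothing available here explains why the place of the hydroxy group matters so much.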